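Swapping the pyridine ring for a trifluoromethylphenyl group

The compounds below may be only part of what the source reports. "The series", "measured", "known", "first", "only" and "open" are said of these compounds alone.

Measured compounds:
- compound 1, `COc1cc(C(=O)c2sc(-c3ccncc3)cc2N)cc(OC)c1OC`: 1810 nM
- compound 2, `COc1cc(C(=O)c2sc(-c3cc(OC)c(OC)c(OC)c3)cc2N)cc(OC)c1OC`: 2300 nM
- compound 3, `COc1cc(C(=O)c2sc(-c3cccs3)cc2N)cc(OC)c1OC`: 9.8 nM

All three share the same core, a five-membered sulfur-containing aromatic ring carrying an amino group and a trimethoxybenzoyl unit, and differ only in the aromatic group attached next to the ring sulfur. In a functional assay on L1210 cells (Mus musculus) for antiproliferative activity (a higher number here means a weaker inhibitor, a lower number a stronger inhibitor), compound 1 gives 1810 nM, the second highest number of the three; compound 2 gives 2300 nM, which lies within the scatter of compound 1, while compound 3 gives 9.8 nM, far lower.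

The new compound 4, `COc1cc(C(=O)c2sc(-c3ccc(C(F)(F)F)cc3)cc2N)cc(OC)c1OC`, changes compound 1 in one place: 4-(trifluoromethyl)phenyl in place of pyridin-4-yl on an aromatic carbon

Within the data shown here, the one directly relevant step is a 180-fold lower number from compound 1 to compound 3 (2.27 log units; beyond the scatter), showing that the group at this position can shift the number enormously. Compound 2, also carrying a six-membered carbon-only ring at this position, gives a number close to compound 1, so a six-membered ring by itself does not bring the large drop seen with compound 3. Because compound 2 shows 2300 nM and compound 3 shows 9.8 nM, compound 4 is expected to land between them, and compound 4 is estimated at 600 nM with a range of 60 nM to 6000 nM, an expected step of a 3.0-fold lower number from compound 1 to compound 4 (0.48 log units; beyond the scatter).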

Compound 4, half-maximal inhibitory concentration: 370 nM
The estimate for compound 4 lay 1.6-fold (0.21 log units) above the measured number, within the range that was stated.
By their numbers in this assay, from the lowest: compound 3; then compound 4; then compounds 1 and 2 (each within the scatter of the next).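

In this assay, replacing pyridin-4-yl with 4-(trifluoromethyl)phenyl brings a 4.9-fold lower number from compound 1 to compound 4 (0.69 log units; beyond the scatter), and since compound 2 gives 2300 nM while compound 4 gives 370 nM, two groups built on a six-membered aromatic ring of carbon only can give clearly different numbers here, so what that ring carries matters and not just the ring itself. The thiophen-2-yl group still stands well apart, with a 38-fold higher number from compound 3 to compound 4 (1.58 log units; beyond the scatter), so moving away from pyridin-4-yl to this larger six-membered group recovers only part of the drop seen with the five-membered ring of compound 3. Nothing measured here explains why these groups differ.

As far as these compounds go, it remains open whether a plain phenyl ring, or a 4-methoxyphenyl or 4-chlorophenyl group, would give a number nearer to compound 4 or to compound 3. From the compounds shown here alone, it also remains open whether the low number of compound 3 is special to thiophen-2-yl or would be shared by another five-membered aromatic ring such as furan-2-yl.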